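Three Limits and a Methoxy Analogue

The source may report more compounds than this note shows. Statements on the series, on what has been measured and on what is new or still open speak of the compounds shown alone.

Compound 3, `C/C(=C\c1cc(-c2ccc(C(F)(F)F)cc2)cs1)C(N)=O`, is one of three close analogues tested in a functional assay on BGC-823 cells (Homo sapiens) for cytotoxicity, read by CCK-8 assay, with a stated time of 24 h; on this read-out lower numbers stand for stronger inhibition and higher numbers for weaker inhibition. In this assay compound 3 gives > 50000 nM, which is a limit of the assay rather than a number. Compound 1, `C/C(=C\c1cc(-c2ccccc2)cs1)C(N)=O`, gives > 50000 nM in this assay, again a limit. Compound 2, `C/C(=C\c1cc(-c2ccc(C)cc2)cs1)C(N)=O`, gives > 50000 nM in this assay, also a limit. Because all three values sit at the limit of > 50000 nM in this assay, at which 3 of the 3 values shown sit, the steps a step that the two limits leave unreadable from compound 1 to compound 2, a step that the two limits leave unreadable from compound 1 to compound 3 and a step that the two limits leave unreadable from compound 2 to compound 3 cannot be read in size or direction. Compound 4, `COc1ccc(-c2csc(/C=C(\C)C(N)=O)c2)cc1`, differs from compound 3 by methoxy in place of trifluoromethyl on an aromatic carbon. Going by the values given here, no measured step bears directly on this change, and the measured steps among compounds 1, 2 and 3 give no readable size in either direction. For compound 4 the expected step is therefore none beyond the scatter, a number no higher from compound 3 to compound 4 (the limit leaves the size open). Compound 4 is estimated at 50000 nM in this assay, within 20000 nM to 100000 nM, with a limit the most probable report.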

Compound 4, half-maximal inhibitory concentration: > 50000 nM
Compound 4: a limit, no number; the forecaster's own chance of this, stated with the estimate: 80%; the middle value sits exactly at the limit.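

In this assay compound 4 gives > 50000 nM, a limit and not a number. The steps to compound 4 from compound 1, compound 2 and compound 3 therefore cannot be read in size or direction: the limit of > 50000 nM in this assay, at which 4 of the 4 values shown sit.

The compounds shown leave open what number any of these four would give in this assay, and whether any of the changes among them shifts it at all.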